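The compounds below may be only part of what the source reports. "The series", "measured", "known", "first", "only" and "open" are said of these compounds alone.

Compound 1 `C=CCCCCCCCC#CC#CCO` is a straight chain carrying a hydroxy group, two triple bonds and a terminal vinyl. In a functional assay on SK-OV-3 cells (Homo sapiens) for cytotoxicity (a higher number here means that more compound is needed for the effect, a lower number that less compound is needed), compound 1 gives 3.23 ug/mL. Compound 2 `CCCCCCCC#CC#CCO` differs from compound 1 by hydrogen in place of vinyl on a saturated chain carbon, seven bonds along the chain from a triple-bonded carbon; in this assay compound 2 gives 4.63 ug/mL, and the step is a 1.4-fold higher number from compound 1 to compound 2 (0.16 log units; within the scatter). Compound 3 `C=CCCCCCCCC#CC#CCOCC(=O)OC` differs from compound 1 by (methoxycarbonyl)methyl in place of hydrogen on an oxygen on a saturated carbon. In this assay compound 3 reaches only > 30 ug/mL, which is a limit of the assay and not a number. The step is an at least 9.2-fold higher number from compound 1 to compound 3 (0.96 log units; beyond the scatter), resting on (the limit of > 30 ug/mL in this assay, at which 1 of the 3 values shown sits). Compound 4 `CCCCCCCC#CC#CCOCC(=O)OC`, still to be measured, differs from compound 3 by hydrogen in place of vinyl on a saturated chain carbon, seven bonds along the chain from a triple-bonded carbon, the same change that earlier gave a 1.4-fold higher number from compound 1 to compound 2 (0.16 log units; within the scatter). Because that earlier step a 1.4-fold higher number from compound 1 to compound 2 (0.16 log units; within the scatter) stayed within the scatter, compound 4 is expected to show a step that the limit leaves unreadable from compound 3 to compound 4 in this assay, and most likely again only a limit rather than a number. Compound 4 is therefore estimated at about 40 ug/mL, in a range from 20 ug/mL to 100 ug/mL.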

Compound 4, concentration for half-maximal effect: 20.5 ug/mL
Compound 4: middle estimate off by 2.0-fold (0.29 log units), on the high side, within the range that was stated.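

In this assay compound 3 gives > 30 ug/mL, which is a limit of the assay and not a number. Replacing vinyl with hydrogen on the core that carries the (methoxycarbonyl)methyl group therefore yields only a floor, an at least 1.4-fold lower number from compound 3 to compound 4 (0.16 log units; that floor lies within the scatter), and this neither shows that the change carries over unaltered from the core of compound 1 nor shows that it behaves differently: the same change on two cores in this assay, a 1.4-fold higher number (0.16 log units; within the scatter) from compound 1 to compound 2 and an at least 1.4-fold lower number (0.16 log units; that floor lies within the scatter) from compound 3 to compound 4; the limit leaves it open whether they differ. Adding (methoxycarbonyl)methyl on the oxygen gives a higher number on both cores, now also seen as a 4.4-fold higher number from compound 2 to compound 4 (0.65 log units; beyond the scatter), so the direction of this change carries over between these two cores, although the sizes of the two steps cannot be compared: the same change on two cores in this assay, an at least 9.2-fold higher number (0.96 log units; beyond the scatter) from compound 1 to compound 3 and a 4.4-fold higher number (0.65 log units; beyond the scatter) from compound 2 to compound 4; the limit leaves it open whether they differ.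

The compounds shown leave open what a carboxylic acid or an amide in place of the methyl ester would give in this assay. They also leave open how a longer chain would behave, and whether either trend holds beyond these four compounds.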